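The compounds below may be only part of what the source reports. "The series", "measured", "known", "first", "only" and "open" are said of these compounds alone.

Measured so far:
- compound 1, `CCCCCCCc1ccc(NC(=O)N[C@@H](C)c2ccccc2)cc1`: 99%
- compound 2, `C[C@@H](NC(=O)Nc1ccc(C(F)(F)F)cc1)c1ccccc1`: 89%

Both compounds were run in an ADME assay on the whole organism with Oryza sativa as the target, tested at 1 uM; on this read-out lower numbers stand for a stronger effect and higher numbers for a weaker effect at the one concentration tested. In this assay compound 1 gives 99%, and compound 2 gives 89%. Compound 2 holds the smaller of the two numbers, but the gap to compound 1 lies within the usual scatter of repeated measurements, so the two read-outs stand together rather than apart. Among the measured compounds shown here, no pair of measured compounds differs in a single place, so no structural step has yet been tied to a shift in the read-out.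

The next compound is compound 3, `C[C@H](NC(=O)Nc1ccc(C(F)(F)F)cc1)c1ccccc1`, the counterpart of compound 2: the two compounds have the same atoms and bonds and differ only in configuration as drawn: 1 of 1 stereo elements differ; a stereocentre at a saturated chain carbon is drawn R in compound 2 and S in compound 3. For the measured compounds named here, nothing measured so far speaks to what a change of configuration alone does in this assay; the two measured compounds differ in several respects and agree within the scatter. With no shown step to lean on, the expected size of the step in this assay from compound 2 to compound 3 is none beyond the scatter, in no particular direction. Compound 3 is estimated at 90% with a range from 75% to 100%, which is expected to mean a number 1 percentage points higher from compound 2 to compound 3 (within the scatter).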

Compound 3, a percentage reported as activity, at one concentration (the size of the read-out at that concentration, not a potency): 94%
The estimate for compound 3 lay 4 percentage points below the measured number, within the range that was stated.
By their numbers in this assay, from the lowest: compounds 2, 3 and 1 (each within the scatter of the next).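

In this assay, the stereocentre at the saturated chain carbon can now be read on its own: with R drawn on one side and S on the other, the read-out shows a number 5 percentage points higher from compound 2 to compound 3 (within the scatter). At this one concentration, the drawn configuration therefore has no effect that can be told apart from the scatter, and this comparison is clean on the structural side: the fact that compounds 2 and 3 differ only in the configuration as drawn. The aromatic carbon also gains its first single-place step, with trifluoromethyl in place of heptyl giving a number 5 percentage points lower from compound 1 to compound 3 (within the scatter), so even the exchange of these two quite different groups leaves the read-out of this assay within the scatter.

With all three compounds lying within the scatter of their neighbours at a single concentration, neither place has yet been tied to any real shift, and no potency can be drawn from these numbers. Still open, on these data alone, is whether a carboxylic acid, an amine or a short methyl group on that aromatic carbon would give a number that stands apart from these.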